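Swapping the pyridine attachment on a weakly cytotoxic triaryl scaffold

The source may hold more compounds than are shown below. What is called first, only, known or untested is meant among the compounds shown, and "the series" means these compounds.

Measured compounds: compound 2 `Oc1ccc(-c2cc(-c3cccc(Cl)c3)nc(-c3ccccn3)c2)cc1`, 35200 nM; compound 1 `Oc1cccc(-c2cc(-c3cccnc3)nc(-c3cccc(Cl)c3)c2)c1`, "not determined" (no result reported).

In a functional assay on DU-145 cells (Homo sapiens) for cytotoxicity, read by CCK-8 assay and cell counting, with a stated time of 2 days (a higher number here means a weaker inhibitor, a lower number a stronger inhibitor), compound 2 gives 35200 nM, the only number shown, so it stands alone without comparison. Compound 3 `Oc1ccc(-c2cc(-c3cccnc3)nc(-c3cccc(Cl)c3)c2)cc1` differs from it in one place: pyridin-3-yl in place of pyridin-2-yl on an aromatic carbon. Going by the values given here, no measured pair shows this kind of change, so the direction of the step is unknown; the expected step from compound 2 to compound 3 is a 1.0-fold lower number from compound 2 to compound 3 (0.00 log units; within the scatter), not beyond the scatter. Compound 3 is therefore estimated at 35000 nM, within a range of 12000 nM to 100000 nM.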

Compound 3, half-maximal inhibitory concentration: 22900 nM
Beside the measured number, compound 3's estimate is 1.5-fold (0.18 log units) above it, and the stated range covers the measured number.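

In this assay, going by these compounds alone, the exchange of pyridin-2-yl for pyridin-3-yl gives a 1.5-fold lower number from compound 2 to compound 3 (0.19 log units; within the scatter) and is the first step that can be read on this scaffold. At this aromatic carbon, the two pyridine attachments therefore cannot be told apart, as their values lie within the scatter of each other. No measurement at hand offers an explanation for this result.

The compounds shown leave open whether an amine or a carboxylic acid at this position would give a number clearly apart from these two.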